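From 4-bromophenyl to 3-bromophenyl at the limit

The source may hold more compounds than are shown below. What is called first, only, known or untested is meant among the compounds shown, and "the series" means these compounds.

Compound 1 `COc1cc(OC)c(OC)cc1/C=C/COC(=O)/C=C/c1ccc(OC)c(OC)c1`: > 300 mg/kg, a limit
Compound 2 `COc1cc(OC)c(OC)cc1/C=C/COC(=O)/C=C/c1ccc(Br)cc1`: > 300 mg/kg, a limit
Compound 3 `COc1cc(OC)c(OC)cc1/C=C/COC(=O)/C=C/c1cc(OC)c(OC)c(OC)c1`: > 200 mg/kg, a limit

For the measured compounds named here, in a functional assay on the whole organism (strain Kunming) with Mus musculus as the target, with a stated time of 0.5 h (a higher number here means that more compound is needed for the effect, a lower number that less compound is needed), no compound so far has a number, only a limit. Compound 2 stands at the limit of > 300 mg/kg in this assay, at which 2 of the 3 values shown sit. Compound 4 `COc1cc(OC)c(OC)cc1/C=C/COC(=O)/C=C/c1cccc(Br)c1` differs from it as follows: 3-bromophenyl in place of 4-bromophenyl on a double-bonded chain carbon bound to a double-bonded chain carbon, with 3-bromophenyl in place of 4-bromophenyl. Going by the values given here, two measured steps bear on this change: a step that the two limits leave unreadable from compound 1 to compound 2 and a step that the two limits leave unreadable from compound 1 to compound 3. Neither gives a size to carry over, so no direction can be expected. The expected change is no more than the scatter, and the estimated step is a number no higher from compound 2 to compound 4 (the limit leaves the size open). For compound 4 the estimate is 300 mg/kg, with an expected range of 120 mg/kg to 600 mg/kg.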

Compound 4, dose for half-maximal effect: 215 mg/kg
Compound 4: the middle estimate sits 1.4-fold (0.14 log units) above what was measured; the measured number falls inside the stated range.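

In this assay compound 4 is the only compound shown with a number rather than a limit, 215 mg/kg, and the earlier steps cannot be read. With 3-bromophenyl on the double-bonded chain carbon, the result is an at least 1.3-fold lower number from compound 2 to compound 4 (0.14 log units; that floor lies within the scatter), and against 3,4-dimethoxyphenyl it is an at least 1.3-fold lower number from compound 1 to compound 4 (0.14 log units; that floor lies within the scatter), so both sizes remain floors within the scatter. Compound 2 remains a limit: the limit of > 300 mg/kg in this assay, at which 2 of the 4 values shown sit.

On these data alone, whether the number would fall further with 3-chlorophenyl or 3-nitrophenyl at this place stays open. So does the effect of an amide in place of the ester.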